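This account rests on a few compounds, and the source may have more. Where it says the series, first, only, none or still open, it means among the compounds named here.

Measured so far:
compound 1 `CCCNC(=O)NS(=O)(=O)N1CCC(CCNC(=O)c2cc(Cl)ccc2OC)CC1` — 11%
compound 2 `O=C(NC1CCCCC1)NS(=O)(=O)N1CCC(CCNC(=O)C(F)(F)F)CC1` — 13%
compound 3 `O=C(NC[C@@H]1C[C@@H]2C=C[C@@H]1C2)NS(=O)(=O)N1CCC(CCNC(=O)C(F)(F)F)CC1` — 22%

In a functional assay on the whole organism (blood) with Rattus norvegicus as the target, with stated times of 24 h and 1 h, at a dose of 5 mg/kg by the intraperitoneal route (a lower number here means a weaker effect, a higher number a stronger effect of the compound at the dose given), compound 3 and compound 2 lie within the scatter of each other, while compound 1 lies beyond the scatter below compound 3. Compound 4 `O=C(NC[C@@H]1C[C@@H]2C=C[C@@H]1C2)NS(=O)(=O)N1CCC(CCNC(=O)c2nc3ccccc3s2)CC1` carries the change (1,3-benzothiazol-2-yl in place of trifluoromethyl on a carbonyl carbon). Among the measured compounds shown here, no measured step touches this carbonyl carbon: the one step known, a number 9 percentage points higher from compound 2 to compound 3 (within the scatter), concerns the amide-type nitrogen instead. Compound 1, which carries a different group on that carbonyl, gives 11%, and compound 2 with trifluoromethyl gives 13%, so the data give no lean either way. Compound 4 is therefore expected to show a number 2 percentage points lower from compound 3 to compound 4 (within the scatter), nothing beyond the scatter. The estimate for compound 4 is 20%, expected between 8% and 35%.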

Compound 4, a percentage reported as activity, at one dose (the size of the read-out at that dose, not a potency): 24%
For compound 4 the middle estimate is 4 percentage points below the measured one; the range from low to high includes it.
By their numbers in this assay, from the lowest: compounds 1, 2, 3 and 4 (each within the scatter of the next, the first and the last beyond it).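

Among the compounds shown here, this is the first measured change on this carbonyl carbon: in this assay, placing 1,3-benzothiazol-2-yl where trifluoromethyl stood gives a number 2 percentage points higher from compound 3 to compound 4 (within the scatter) and so no readable change. A group with two aromatic rings can therefore stand here without a clear loss of the effect at this dose. Nothing measured here explains why the two groups read alike.

Still open, as far as these compounds go, is whether a group carrying an amine or a carboxylic acid on this carbonyl carbon would shift the effect beyond the scatter. A single dose also leaves the potency of compound 4 unknown.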